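Aminomethyl series: from 1-phenylethyl to benzyl

This account rests on a few compounds, and the source may have more. Where it says the series, first, only, none or still open, it means among the compounds named here.

compound 1 `CCCNC(=O)C1CCN(C(=O)c2cc3sc(C(C)=O)cc3n2Cc2ccc(OC)cc2)CC1`: > 100000 nM
compound 2 `CCCNC(=O)C1CCN(C(=O)c2cc3sc(Br)cc3n2Cc2ccc(OC)cc2)CC1`: > 100000 nM
compound 3 `CCCNC(=O)C1CCN(C(=O)c2cc3sc(CNC(C)c4ccccc4)cc3n2Cc2ccc(OC)cc2)CC1`: 33900 nM
compound 4 `CCCNC(=O)C1CCN(C(=O)c2cc3sc(CNCc4ccccc4)cc3n2Cc2ccc(OC)cc2)CC1`: not yet measured

For the measured compounds named here, in an ADME assay on HEK-293T cells (Homo sapiens) for cytotoxicity, read by luminescence, with a stated time of 24 h (on this read-out lower numbers stand for higher toxicity in this test and higher numbers for lower toxicity in this test), compound 3 gives 33900 nM, the only true number in the set. The entries for compound 1 and compound 2 are limits of the assay, not numbers, as the limit of > 100000 nM in this assay, at which 2 of the 3 values shown sit, records.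

The next structural change is hydrogen in place of methyl on a saturated chain carbon bound to an amine nitrogen and an aromatic carbon, so that 1-phenylethyl becomes benzyl. Going by the values given here, two measured steps bear on it, and only loosely: an at least 2.9-fold lower number from compound 1 to compound 3 (0.46 log units; beyond the scatter) and an at least 2.9-fold lower number from compound 2 to compound 3 (0.46 log units; beyond the scatter). Each brings in the whole ((1-phenylethyl)amino)methyl group and each gives only a minimum size. Among the compounds with values here, no measured step isolates the methyl. In this assay no step beyond the scatter is therefore expected, with compound 3 at 33900 nM as the anchor. The expected step is a 1.1-fold higher number from compound 3 to compound 4 (0.05 log units; within the scatter). The estimate for compound 4 is 38000 nM, with an expected range of 15000 nM to 95000 nM.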

Compound 4, half-maximal cytotoxic concentration: 46800 nM
Compound 4: middle estimate off by 1.2-fold (0.09 log units), on the low side; the range from low to high includes it.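

The methyl on the saturated chain carbon bound to an amine nitrogen and an aromatic carbon can now be read on its own: in this assay, hydrogen in its place gives a 1.4-fold higher number from compound 3 to compound 4 (0.14 log units; within the scatter), so this position shows no step beyond the scatter for this change. The aminomethyl effect does not depend on that methyl, as the benzyl form still gives an at least 2.1-fold lower number from compound 2 to compound 4 (0.32 log units; beyond the scatter) and an at least 2.1-fold lower number from compound 1 to compound 4 (0.32 log units; beyond the scatter). Both of these sizes are minimums only, and no true size can be read from them: the limit of > 100000 nM in this assay, at which 2 of the 4 values shown sit.

Still open, as far as these compounds go, is whether a larger group on the same carbon, such as ethyl or phenyl, would stay within the scatter. Also open, from the compounds shown here alone, is whether the step survives with a dimethylamino group or morpholine in place of the benzylamino group.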